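Amide in place of the urea tail on compound 2

A few compounds are considered here, and "the series" means these few. Any claim that something is new, unique, unknown or untested is made for them only; others in the source may bear on it.

Compound 1 `Nc1ccc2cc(NC(=O)CCc3ccc(C(F)(F)F)cc3)ccc2n1` carries the shared core with an amino group and, in a functional assay on HEK293 cells for activation of melanin-concentrating hormone receptor 1 (Rattus norvegicus), read by inositol phosphate accumulation (on this read-out higher numbers stand for an effect only at larger amounts of compound and lower numbers for an effect already at smaller amounts), compound 1 gives 720 nM. Compound 2 `CNC(=O)NC1CCN(c2ccc3cc(NC(=O)CCc4ccc(C(F)(F)F)cc4)ccc3n2)C1` differs from it by 3-((methylcarbamoyl)amino)pyrrolidin-1-yl in place of amino on an aromatic carbon, and in this assay compound 2 gives 30 nM. Among the compounds with values here, that step, a 24-fold lower number from compound 1 to compound 2 (1.38 log units; beyond the scatter), is the only measured one, and it leaves compound 2 with the lowest of the two numbers so far.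

Compound 3 `CC(C)C(=O)NC1CCN(c2ccc3cc(NC(=O)CCc4ccc(C(F)(F)F)cc4)ccc3n2)C1` is the next variation on compound 2. The change is isopropyl in place of methylamino on a carbonyl carbon, so the (methylcarbamoyl)amino group becomes (isopropylcarbonyl)amino while the pyrrolidine ring and the rest of the core remain unchanged.

Within the data shown here, no measured step touches this part of compound 2; the one step known moved the whole pyrrolidinyl group in at once and does not separate the methylcarbamoyl part from the rest. With nothing to anchor a direction, the expected step of a 1.3-fold higher number from compound 2 to compound 3 (0.12 log units; within the scatter) is small, quite possibly within the scatter. Compound 3 is therefore estimated at 40 nM in this assay, with a range from 12 nM to 130 nM.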

Compound 3, half-maximal effective concentration: 90 nM
Compound 3: middle estimate off by 2.3-fold (0.35 log units), on the low side; the range from low to high includes it.
By their numbers in this assay, from the lowest: compound 2; then compound 3; then compound 1.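

In this assay, isopropyl in place of methylamino on the carbonyl carbon gives a 3.0-fold higher number from compound 2 to compound 3 (0.48 log units; beyond the scatter) and so shows that the group on this carbonyl carbon matters on its own, which the earlier step, with the whole pyrrolidinyl group entering at once, could not separate. Much of the difference from the amino compound remains, with an 8.0-fold lower number from compound 1 to compound 3 (0.90 log units; beyond the scatter) for the 3-((isopropylcarbonyl)amino)pyrrolidin-1-yl group, so among these three compounds the methylcarbamoyl tail is not needed for a number well under that of compound 1, though compound 2 keeps the lowest number. The change swaps a nitrogen and its hydrogen-bond donor for an all-carbon group, and no measurement at hand links the higher number to either feature.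

As far as these compounds go, what stays open is whether the nitrogen or the shape of the group counts here: dimethylamino on the carbonyl carbon would keep the nitrogen without its hydrogen, while ethyl would keep the all-carbon character with a shorter group. Also open, from the compounds shown here alone, is whether a longer chain or a cyclopropyl on the carbonyl carbon moves the number further in either direction.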